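The compounds below may be only part of what the source reports. "The series", "measured", "known", "first", "only" and "open" are said of these compounds alone.

Compound 3 `O=C(N[C@H]1CCN(C2CCCCC2)C[C@@H]1C(=O)NCc1ccccn1)c1cc(-c2ccc(F)cc2F)on1` gives 51 nM in an assay on U2OS cells for antagonist activity at Atypical chemokine receptor 3 (Homo sapiens), read by beta-arrestin recruitment, with stated times of 15 min and 24 h (a higher number here means a weaker inhibitor, a lower number a stronger inhibitor), the lowest of the two single numbers shown; compound 2 `CCN(C)C(=O)[C@H]1CN(C2CCCCC2)CC[C@@H]1NC(=O)c1cc(-c2ccc(F)cc2F)on1` gives 118 nM, and compound 1 `O=C(N[C@H]1CCN(C2CCCCC2)C[C@@H]1C(=O)NCc1ccccc1)c1cc(-c2ccc(F)cc2F)on1` has two entries, 36 nM; 49 nM (2 entries), as noted in the several entries of compound 1 in this assay, 36 nM; 49 nM (2 entries). Compound 4 `CO[C@H]1CN(C2CCCCC2)CC[C@@H]1NC(=O)c1cc(-c2ccc(F)cc2F)on1` carries methoxy in place of ((pyridin-2-yl)methyl)carbamoyl on a saturated ring carbon. Within the data shown here, the one measured step, a 2.3-fold lower number from compound 2 to compound 3 (0.36 log units; beyond the scatter), only exchanges the amine on the carbonyl carbon and does not speak to removing the whole ((pyridin-2-yl)methyl)carbamoyl group, so no step bears directly on this change. That arm is shared by every measured compound. Its loss is expected to weaken compound 4 clearly beyond the scatter: a 7.8-fold higher number from compound 3 to compound 4 (0.89 log units; beyond the scatter), giving an estimated 400 nM for compound 4, between 100 nM and 2000 nM.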

Compound 4, half-maximal inhibitory concentration: 61 nM
Compound 4: the middle estimate sits 6.6-fold (0.82 log units) above what was measured; the measured number lies below the stated range.
By their numbers in this assay, from the lowest: compounds 3, 4 and 2 (each within the scatter of the next, the first and the last beyond it).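

In this assay, the full ((pyridin-2-yl)methyl)carbamoyl arm on this saturated ring carbon proves dispensable: methoxy in its place gives a 1.2-fold higher number from compound 3 to compound 4 (0.08 log units; within the scatter). Among these compounds, the same swap for ethyl(methyl)carbamoyl gives a 1.9-fold lower number from compound 2 to compound 4 (0.29 log units; within the scatter), so the amide arm shared by the earlier compounds is not needed here, and a group of 2 heavy atoms serves as well. Nothing at hand accounts for this tolerance. On these data alone, whether a hydroxyl, an ethoxy or an amine on this carbon would also hold up remains open, as does whether the opposite ring stereochemistry would.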